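The source may report more compounds than this note shows. Statements on the series, on what has been measured and on what is new or still open speak of the compounds shown alone.

In an ADME assay (liver) for metabolic stability, with Liver microsome (Homo sapiens) as the target, using microsomes (on this read-out higher numbers stand for fast clearance and lower numbers for slow clearance), compound 1 (`c1ccc(CNc2nnc(-c3c[nH]c4ncccc34)o2)cc1`) gives 31 mL.min-1.g-1, and compound 2 (`Fc1ccccc1CNc1nnc(-c2c[nH]c3ncccc23)o1`) gives 32 mL.min-1.g-1. Fluoro in place of hydrogen on an aromatic carbon amounts to a 1.0-fold higher number from compound 1 to compound 2 (0.01 log units; within the scatter).

Compound 3 (`c1ccc(CNc2nnc(-c3c[nH]c4ncccc34)o2)nc1`) gives < 14 mL.min-1.g-1, which is a limit of the assay and not a number. Among the measured compounds, only compound 3 stands at the limit of < 14 mL.min-1.g-1 in this assay, at which 1 of the 3 values shown sits. Pyridin-2-yl in place of phenyl gives an at least 2.2-fold lower number from compound 1 to compound 3 (0.34 log units; beyond the scatter), and pyridin-2-yl in place of 2-fluorophenyl gives an at least 2.2-fold lower number from compound 2 to compound 3 (0.35 log units; beyond the scatter).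

Compound 4 (`c1cnc2[nH]cc(-c3nnc(NCc4ccncc4)o3)c2c1`) carries pyridin-4-yl in place of pyridin-2-yl on a saturated chain carbon bound to a nitrogen on an aromatic ring. The two have the same atoms, joined differently. Among the measured compounds shown here, no measured step exchanges one pyridinyl group for another, so the nearest guide is the move from phenyl to pyridin-2-yl, with an at least 2.2-fold lower number from compound 1 to compound 3 (0.34 log units; beyond the scatter) and an at least 2.2-fold lower number from compound 2 to compound 3 (0.35 log units; beyond the scatter) both beyond the scatter. Compound 4 keeps a pyridinyl group in that place, so it is expected to stay close to compound 3, with some room upward.

The expected change is an at least 1.0-fold higher number from compound 3 to compound 4 (0.02 log units; that floor lies within the scatter), which means no clear step beyond the scatter is anticipated. In this assay the estimate for compound 4 is 15 mL.min-1.g-1, within a range of 7 mL.min-1.g-1 to 30 mL.min-1.g-1.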

Compound 4, intrinsic clearance in microsomes: < 14 mL.min-1.g-1
Compound 4: a limit, no number; the forecaster's own chance of this, stated with the estimate: 45%; middle value at least 1.0-fold (0.02 log units) from the limit.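

In this assay, the lower reading on a saturated chain carbon bound to a nitrogen on an aromatic ring is not confined to pyridin-2-yl: pyridin-4-yl in place of phenyl gives an at least 2.2-fold lower number from compound 1 to compound 4 (0.34 log units; beyond the scatter), and pyridin-4-yl in place of 2-fluorophenyl gives an at least 2.2-fold lower number from compound 2 to compound 4 (0.35 log units; beyond the scatter). Both of these steps are minimum sizes, and they show that the change from a phenyl group to a pyridinyl group holds for two different attachments of the pyridinyl ring. Compound 3 and compound 4 both stand at a limit of the assay and not at a number, so the step between them cannot be read and the two pyridinyl groups cannot be ranked: the limit of < 14 mL.min-1.g-1 in this assay, at which 2 of the 4 values shown sit.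

As far as these compounds go, it remains open how far compound 3 and compound 4 lie under that limit and whether they differ at all. Also open, from the compounds shown here alone, is whether pyridin-3-yl, or a pyrimidinyl group, at this place gives a reading like those of the two pyridinyl compounds, and whether a longer chain than the (pyridin-4-yl)methyl link keeps it.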